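Cyano in Place of Methylsulfonyl on a Sub-Nanomolar Series

The source may report more compounds than this note shows. Statements on the series, on what has been measured and on what is new or still open speak of the compounds shown alone.

The measured compounds:
Compound 1 `CN(C)CC[C@H](CSc1ccccc1)Nc1ccc(S(=O)(=O)NC(=O)c2ccc(N3CCN(Cc4ccccc4-c4ccc(Cl)cc4)CC3)cc2)cc1OC(F)(F)F`. In an assay on isolated protein for displacement of a labelled ligand from Bcl2-associated agonist of cell death (Homo sapiens), read by fluorescence polarization (on this read-out lower numbers stand for stronger inhibition and higher numbers for weaker inhibition), compound 1 gives < 1 nM, a limit of the assay rather than a number.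
Compound 2 `CN(C)CC[C@H](CSc1ccccc1)Nc1ccc(S(=O)(=O)NC(=O)c2ccc(N3CCN(Cc4ccccc4-c4ccc(Cl)cc4)CC3)cc2)cc1C(F)(F)F`. In this assay compound 2 gives < 1 nM, again a limit.
Compound 3 `CN(C)CC[C@H](CSc1ccccc1)Nc1ccc(S(=O)(=O)NC(=O)c2ccc(N3CCN(Cc4ccccc4-c4ccc(Cl)cc4)CC3)cc2)cc1S(C)(=O)=O`. In this assay compound 3 gives < 1 nM, also a limit.

Compound 3 therefore stands where every value shown stands, at the limit of < 1 nM in this assay, at which 3 of the 3 values shown sit. No one of the three can be ranked against another. The steps among them, a step that the two limits leave unreadable from compound 1 to compound 2, a step that the two limits leave unreadable from compound 1 to compound 3 and a step that the two limits leave unreadable from compound 2 to compound 3, are all unreadable in size. Each of their ends is a limit.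

Compound 4 `CN(C)CC[C@H](CSc1ccccc1)Nc1ccc(S(=O)(=O)NC(=O)c2ccc(N3CCN(Cc4ccccc4-c4ccc(Cl)cc4)CC3)cc2)cc1C#N` differs from compound 3 by cyano in place of methylsulfonyl on an aromatic carbon.

The three earlier steps all changed the group at the same place, and none of them moved a value away from the limit. They give no readable size, so the expectation for compound 4 can only be that the same place tolerates another small exchange. The step is expected to be a step that the limit leaves unreadable from compound 3 to compound 4, that is none beyond the scatter. For compound 4 in this assay the estimate is 0.6 nM, with a range from 0.1 nM to 4 nM, and most likely the assay will again report only its limit.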

Compound 4, inhibition constant: < 1 nM
Compound 4 was reported as a limit; the forecaster's own chance of this, stated with the estimate: 70%; the middle value lies beyond the limit too.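

The steps from compound 1, compound 2 and compound 3 to compound 4 cannot be read in size, because each of their ends is a limit of this assay: the limit of < 1 nM in this assay, at which 4 of the 4 values shown sit.

The compounds shown leave open how these four rank against one another, and whether any exchange of the group at this place would yield a readable value.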